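Methylsulfanyl for Methoxy: Compound 3 Beside Compound 2

The source may report more compounds than this note shows. Statements on the series, on what has been measured and on what is new or still open speak of the compounds shown alone.

Compound 2 `COc1ncnc2c1c(-c1cccs1)cn2[C@@H]1O[C@H](CO)[C@@H](O)[C@H]1O` gives 12100 nM in a functional assay on CEM-DNR-bulk cells (Homo sapiens), read by MTT assay, with a stated time of 72 h; a higher number here means a weaker inhibitor, a lower number a stronger inhibitor. Going by the values given here, that is the highest of the two numbers measured so far. The nearest is compound 1 `COc1ncnc2c1c(-c1ccsc1)cn2[C@@H]1O[C@H](CO)[C@@H](O)[C@H]1O`, which gives 7640 nM in this assay, and the step of a 1.6-fold higher number from compound 1 to compound 2 (0.20 log units; within the scatter) lies within the scatter, so the two cannot be ordered. Compound 3 `CSc1ncnc2c1c(-c1cccs1)cn2[C@@H]1O[C@H](CO)[C@@H](O)[C@H]1O` differs from compound 2 in one place: methylsulfanyl in place of methoxy on an aromatic carbon. Among the compounds with values here, no measured step bears on this change. Within the data shown here, the only step available, a 1.6-fold higher number from compound 1 to compound 2 (0.20 log units; within the scatter), concerns the exchange of thiophen-3-yl for thiophen-2-yl and says nothing about the methoxy. With nothing to guide it, the expected step of a 1.1-fold lower number from compound 2 to compound 3 (0.04 log units; within the scatter) is none beyond the scatter, in no settled direction. Compound 3 is therefore estimated at 11000 nM in this assay, with a range from 3000 nM to 40000 nM. Among the measured compounds shown here, the range is wide, as no measured step informs it.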

Compound 3, half-maximal inhibitory concentration: > 20000 nM
Compound 3: a limit, no number; the forecaster's own chance of this, stated with the estimate: 10%; at least 1.8-fold (0.25 log units) between middle value and limit.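

The value of compound 3 in this assay is a limit of the assay and not a number: the limit of > 20000 nM in this assay, at which 1 of the 3 values shown sits.

Going by these compounds alone, this is the first reading of a change at this aromatic carbon next to the ring nitrogen, since the earlier step concerned only the thiophene. Methylsulfanyl in place of methoxy reads as an at least 1.6-fold higher number from compound 2 to compound 3 (0.21 log units; that floor lies within the scatter) and so shows no gain in strength from this exchange, while a real loss is neither established nor excluded, since the floor of the step does not clear the scatter.

As far as these compounds go, whether methylsulfanyl would act the same way with the thiophen-3-yl group of compound 1 stays open. So does the effect of an amine or a longer chain such as ethoxy at this position, and with it whether any group here gives a lower number than methoxy.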